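This account rests on a few compounds, and the source may have more. Where it says the series, first, only, none or still open, it means among the compounds named here.

The series keeps one shared core and varies the substituent on the amide nitrogen. In a functional assay on MCF7 cells (Homo sapiens) for inhibition, read by MTT assay, with a stated time of 48 h (on this read-out lower numbers stand for stronger inhibition and higher numbers for weaker inhibition), compound 1 (`CCCCCCCCNC(=O)/C=C/c1c(/C=C/c2ccc(OC)cc2)cc(OC)cc1OC`) gives 4280 nM, compound 2 (`CCCCNC(=O)/C=C/c1c(/C=C/c2ccc(OC)cc2)cc(OC)cc1OC`) gives 1330 nM and compound 3 (`C#CCNC(=O)/C=C/c1c(/C=C/c2ccc(OC)cc2)cc(OC)cc1OC`) gives 4560 nM. Compound 1 therefore belongs to the upper pair on these numbers: the measured steps are a 1.1-fold higher number from compound 1 to compound 3 (0.03 log units; within the scatter) and a 3.2-fold lower number from compound 1 to compound 2 (0.51 log units; beyond the scatter).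

Compound 4 (`CCCCN(CCCC)C(=O)/C=C/c1c(/C=C/c2ccc(OC)cc2)cc(OC)cc1OC`) differs from compound 1 at one place: dibutylamino in place of octylamino on a carbonyl carbon. Dibutylamino stands in place of octylamino on a carbonyl carbon, so the two have the same atoms, joined differently. Among the compounds with values here, no measured step makes this change or removes the amide hydrogen, so the evidence is indirect. The nearest guides are the changes to the chain on the same nitrogen. Those steps stay modest or smaller in this assay: besides the two above, there is a 3.4-fold higher number from compound 2 to compound 3 (0.54 log units; beyond the scatter). With three values spanning so narrow a range, a modest move in either direction remains possible, but no direction is supported. The estimated step is a 1.1-fold lower number from compound 1 to compound 4 (0.05 log units; within the scatter), so no change beyond the scatter is expected. For compound 4 the expected value is 3800 nM, within an estimated range of 1500 nM to 9500 nM.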

Compound 4, half-maximal inhibitory concentration: 3990 nM
Estimate against measurement, compound 4: 1.1-fold (0.02 log units) below, within the range that was stated.
By their numbers in this assay, from the lowest: compound 2; then compounds 4, 1 and 3 (each within the scatter of the next).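

In this assay, the step of a 1.1-fold lower number from compound 1 to compound 4 (0.03 log units; within the scatter) shows that rearranging the same atoms from octylamino to dibutylamino on the carbonyl carbon, which also removes the amide hydrogen, leaves the number within the scatter. The step of a 1.1-fold lower number from compound 3 to compound 4 (0.06 log units; within the scatter) is also within the scatter, so the amide hydrogen does not separate compound 4 from compound 1 or compound 3, which both keep it; only the butylamino of compound 2 stands apart. Within the data shown here, the step of a 3.0-fold higher number from compound 2 to compound 4 (0.48 log units; beyond the scatter) adds the first direct evidence at the nitrogen itself, as a second butyl on the amide-type nitrogen gives a modest change beyond the scatter, but no measurement on these compounds accounts for any of these steps.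

As far as these compounds go, with a single disubstituted amide in the set, it remains open whether the level seen for compound 4 holds for a shorter pair such as dimethylamino or a longer pair such as dihexylamino. From the compounds shown here alone, it is also open whether the separate position of compound 2 persists among nearby chains such as propylamino and pentylamino, or with a chain ending in a carboxylic acid or an amine.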